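This account rests on a few compounds, and the source may have more. Where it says the series, first, only, none or still open, it means among the compounds named here.

Measured compounds in a functional assay on MIA PaCa-2 cells (Homo sapiens) for inhibition, read by MTT assay, with a stated time of 7 days; a lower number here means a stronger inhibitor, a higher number a weaker inhibitor:
- compound 1, `CCN(CC)S(=O)(=O)c1ccc(S(=O)(=O)N2CCC[C@@H](C(=O)N3CCN(c4nc(C)no4)CC3)C2)cc1`, gives 250 nM
- compound 2, `CCN(CC)S(=O)(=O)c1ccc(S(=O)(=O)N2CCC[C@@H](C(=O)NC3CN(C(=O)NC(C)(C)C)C3)C2)cc1`, gives 3400 nM
- compound 3, `CCN(CC)S(=O)(=O)c1ccc(S(=O)(=O)N2CCC[C@@H](c3nc(C)no3)C2)cc1`, gives 4100 nM

Compound 3 lies well apart from compound 1 and at about the level of compound 2. Compound 4, `CCN(CC)S(=O)(=O)c1ccc(S(=O)(=O)N2CCC[C@@H](C(=O)NC)C2)cc1`, differs from compound 3 in one place: methylcarbamoyl in place of 3-methyl-1,2,4-oxadiazol-5-yl on a saturated ring carbon. Among the compounds with values here, the only measured step, a 14-fold higher number from compound 1 to compound 2 (1.13 log units; beyond the scatter), changes a group on a carbonyl carbon, not a group on the saturated ring carbon, so it bears on the present step only loosely, showing that a group swap at the edge of this core can move the number a great deal. Within the data shown here, no measured step tests a small amide in this place, so no clear direction can be drawn. Compound 4 is therefore expected to stay near compound 3, with a step of a 1.2-fold higher number from compound 3 to compound 4 (0.09 log units; within the scatter), and is estimated at 5000 nM, within 1500 nM to 20000 nM.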

Compound 4, half-maximal inhibitory concentration: 8600 nM
For compound 4 the middle estimate is 1.7-fold (0.24 log units) below the measured one; measured number inside the range.
By their numbers in this assay, from the lowest: compound 1; then compounds 2 and 3 (each within the scatter of the next); then compound 4.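

In this assay, replacing the ring-bound 3-methyl-1,2,4-oxadiazol-5-yl with methylcarbamoyl gives a 2.1-fold higher number from compound 3 to compound 4 (0.32 log units; beyond the scatter), a modest loss on this saturated ring carbon. On the carbonyl carbon, methylamino is modestly weaker than the azetidine-bearing group, with a 2.5-fold higher number from compound 2 to compound 4 (0.40 log units; beyond the scatter), but far weaker than the piperazine-bearing group, with a 34-fold higher number from compound 1 to compound 4 (1.54 log units; beyond the scatter), which places most of the activity shown here with that larger group. No available evidence explains these differences. Going by these compounds, it remains open how a carboxylic acid or a primary amine would behave on the saturated ring carbon. A longer chain on the amide nitrogen is also untested among the compounds shown.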